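Fluoro Analogue of Compound 1 Awaits Its Inhibition Number

The source may hold more compounds than are shown below. What is called first, only, known or untested is meant among the compounds shown, and "the series" means these compounds.

Going by the values given here, compound 1 `C/N=C(\S)n1nc(-c2ccccc2)nc1N` gives 54% in a functional assay on the whole organism for inhibition, with Rattus norvegicus as the target, at a dose of 30 mg/kg (on this read-out higher numbers stand for more inhibition at the one dose given (going by the name of the read-out) and lower numbers for less inhibition), the higher of the two numbers measured so far. Its nearest neighbour, compound 2 `C/N=C(\S)n1nc(-c2ccccc2Cl)nc1N`, gives 18% in this assay. The change of chloro in place of hydrogen on an aromatic carbon brought a number 36 percentage points lower from compound 1 to compound 2 (beyond the scatter). Compound 3 `C/N=C(\S)n1nc(-c2ccc(F)cc2)nc1N` differs from compound 1 by fluoro in place of hydrogen on an aromatic carbon. Among the compounds with values here, the only measured step that bears on this is that large downward halogen-for-hydrogen step on the same ring, so a smaller drop is expected here too, and the expected step is estimated as a number 14 percentage points lower from compound 1 to compound 3 (beyond the scatter). Compound 3 is therefore estimated at 40%, in a range from 20% to 60%.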

Compound 3, a percentage reported as inhibition, in the whole organism at one dose (the size of the read-out at that dose, not a potency): 73%
Estimate against measurement, compound 3: 33 percentage points below, outside the stated range (above it).
By their numbers in this assay, from the lowest: compound 2; then compound 1; then compound 3.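

In this assay, going by these compounds alone, fluoro in place of hydrogen on an aromatic carbon, para to a large group, brings a number 19 percentage points higher from compound 1 to compound 3 (beyond the scatter) and so gives the first upward step on this ring. The earlier step of a number 36 percentage points lower from compound 1 to compound 2 (beyond the scatter) showed only a loss, so halogen in place of hydrogen does not go one way across these compounds, with compound 2 falling and compound 3 rising against compound 1.

The compounds shown leave open whether the gain belongs to fluoro itself or to its place, and how chloro, a methoxy group or an amine would read para to a large group. Nothing given here accounts for the rise.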